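This account rests on a few compounds, and the source may have more. Where it says the series, first, only, none or still open, it means among the compounds named here.

Compound 1 `COc1cc(-c2nn(-c3cccc(NC(=O)Nc4ccc(Cl)c(Cl)c4)c3)cc2-c2ccncc2)ccc1Cl` stands second highest of three numbers in a functional assay on SNB-75 cells (Homo sapiens) for inhibition, read by sulforhodamine B assay, with a stated time of 48 h (a higher number here means a weaker inhibitor of growth, a lower number a stronger inhibitor of growth), at 5170 nM. Compound 2 `O=C(Nc1cccc(-n2cc(-c3ccncc3)c(-c3ccc(Cl)c(O)c3)n2)c1)Nc1ccc(Cl)c(Cl)c1` gives 12200 nM, and compound 3 `O=C(Nc1cccc(-n2cc(-c3ccncc3)c(-c3ccc(Cl)c(O)c3)n2)c1)Nc1cc(C(F)(F)F)cc(C(F)(F)F)c1` gives 2180 nM. The only step joining two of these compounds, a 2.4-fold higher number from compound 1 to compound 2 (0.37 log units; beyond the scatter), is modest. Compound 4 `COc1cc(-c2nn(-c3cccc(NC(=O)c4ccccc4)c3)cc2-c2ccncc2)ccc1Cl` derives from compound 1 through (phenyl in place of (3,4-dichlorophenyl)amino on a carbonyl carbon). Among the compounds with values here, no measured step covers this kind of change; the values of compounds 2 and 3 show only that exchanging the (3,4-dichlorophenyl)amino group for another ring alters the number. With a hydrogen-bond donor and both chlorines gone, compound 4 is expected to inhibit growth less strongly than compound 1, the step being estimated as a 2.9-fold higher number from compound 1 to compound 4 (0.46 log units; beyond the scatter). Compound 4 is therefore expected to give 15000 nM, within 5000 nM to 50000 nM.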

Compound 4, concentration for total growth inhibition: > 100000 nM
Compound 4: only a limit was reported (the forecaster's own chance of this, stated with the estimate: 15%); middle value at least 6.6-fold (0.82 log units) away from the limit.
By their numbers in this assay, from the lowest: compound 3; then compound 1; then compound 2. At a limit, above all of these: compound 4.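

In this assay compound 4 gives only a limit, > 100000 nM, and not a number. Even so, the first change shown on this carbonyl carbon is a large one, an at least 19-fold higher number from compound 1 to compound 4 (1.28 log units; beyond the scatter), and it exceeds the only earlier step, which lay at the oxygen on the aromatic ring. Growth inhibition in this series therefore depends strongly on the (3,4-dichlorophenyl)amino group at this place. The compounds shown leave open whether the amino nitrogen or the two chlorines carry this difference: a phenylamino group or a 3,4-dichlorophenyl group on the same carbonyl carbon would separate the two.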